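The compounds below may be only part of what the source reports. "The series", "measured", "known", "first", "only" and "open" are said of these compounds alone.

Working notes on the series.

Three compounds share one core. Compound 1 `COc1cc(-c2nn(-c3cccc(NC(=O)c4cccc(C(F)(F)F)c4)c3)cc2-c2ccncc2)ccc1Cl` carries a 3-(trifluoromethyl)phenyl on the carbonyl carbon; compound 2 `COc1cc(-c2nn(-c3cccc(NC(=O)Nc4ccc(Cl)c(Cl)c4)c3)cc2-c2ccncc2)ccc1Cl` carries a (3,4-dichlorophenyl)amino there; compound 3 `COc1cc(-c2nn(-c3cccc(NC(=O)c4ccc(Cl)c(C(F)(F)F)c4)c3)cc2-c2ccncc2)ccc1Cl` carries a 4-chloro-3-(trifluoromethyl)phenyl there.

In a functional assay on U-251 cells (Homo sapiens) for inhibition, read by sulforhodamine B assay, with a stated time of 48 h (a lower number here means that less compound is tolerated, a higher number that more compound is tolerated), compound 1 gives only a limit, > 50000 nM. In this assay compound 2 also gives only a limit, > 50000 nM. Compound 3 likewise gives only a limit, > 32500 nM. Compound 3 therefore stands at no readable number; it sits at the limit of > 32500 nM in this assay, at which 1 of the 3 values shown sits, the other two sit at the limit of > 50000 nM in this assay, at which 2 of the 3 values shown sit.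

The measured steps are accordingly all unreadable: a step that the two limits leave unreadable from compound 1 to compound 2, a step that the two limits leave unreadable from compound 1 to compound 3 and a step that the two limits leave unreadable from compound 2 to compound 3. None of them gives a size or a direction.

Compound 4 `COc1cc(-c2nn(-c3cccc(NC(=O)Nc4ccc(Cl)c(C(F)(F)F)c4)c3)cc2-c2ccncc2)ccc1Cl` differs from compound 3 by (4-chloro-3-(trifluoromethyl)phenyl)amino in place of 4-chloro-3-(trifluoromethyl)phenyl on a carbonyl carbon. The closest measured parallel is the change from compound 1 to compound 2, an aryl to arylamino swap on the same carbonyl carbon, which stayed at a limit on both sides. No step shown bears a readable size on this change, so no movement beyond the scatter is expected in this assay, and compound 4 is expected to remain at a limit as well.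

For compound 4 the estimate in this assay is 50000 nM, within 20000 nM to 150000 nM, an expected step that the limit leaves unreadable from compound 3 to compound 4 from compound 3.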

Compound 4, concentration lethal to 50% of the cells: 24700 nM
Estimate against measurement, compound 4: 2.0-fold (0.31 log units) above; low and high end bracket the measured number.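

Among these compounds, compound 4 is the only one of the four compounds with a number rather than a limit in this assay, so the change on this carbonyl carbon now has a direction: an at least 1.3-fold lower number from compound 3 to compound 4 (0.11 log units; that floor lies within the scatter). The other two steps to compound 4 point the same way: an at least 2.0-fold lower number from compound 2 to compound 4 (0.30 log units; that floor lies within the scatter), and an at least 2.0-fold lower number from compound 1 to compound 4 (0.30 log units; that floor lies within the scatter). Compound 2 also carries an arylamino group on this carbonyl carbon and gives only a limit, > 50000 nM, so the amino group alone does not yield a number here.

As far as these compounds go, each step is only a floor, so whether any of them truly exceeds the scatter remains open. Also open, from the compounds shown here alone, is whether a carboxylic acid or a morpholine in place of the chloro would keep a number in this assay.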